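Ethoxy added to compound 3

The source may hold more compounds than are shown below. What is called first, only, known or untested is meant among the compounds shown, and "the series" means these compounds.

Of the compounds shown here, three sharing one core have been measured in a functional assay on A549 cells (Homo sapiens) for antiproliferative activity, read by MTT assay, with a stated time of 72 h; a higher number here means a weaker inhibitor, a lower number a stronger inhibitor. Here compound 1 `COc1cc(C(=O)c2sc3ccccc3c2-c2ccc(Cl)cc2)cc(OC)c1OC`, carrying 4-chlorophenyl, gives 7500 nM. Compound 2 `COc1ccc(OC)c(-c2c(C(=O)c3cc(OC)c(OC)c(OC)c3)sc3ccccc23)c1`, carrying 2,5-dimethoxyphenyl, reaches only a limit of the assay, > 10000 nM. Compound 3 `COc1cc(C(=O)c2sc3ccccc3c2Nc2ccccc2)cc(OC)c1OC`, carrying anilino, gives 3000 nM, the lowest number of the set, and compound 1 is its nearest neighbour with a measured number.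

Compound 4 `CCOc1ccc(Nc2c(C(=O)c3cc(OC)c(OC)c(OC)c3)sc3ccccc23)cc1` keeps the anilino of compound 3 and has ethoxy in place of hydrogen on an aromatic carbon, para to a large group: ethoxy in place of hydrogen on an aromatic carbon.

Among the measured compounds shown here, no measured step makes this change directly. The closest guides are the two steps that exchange the whole group at the same place: a 2.5-fold lower number from compound 1 to compound 3 (0.40 log units; beyond the scatter) and an at least 3.3-fold lower number from compound 2 to compound 3 (0.52 log units; beyond the scatter). Both are modest or larger, but each swaps one complete group for another, so they give a rough scale for size and no direction for adding ethoxy to the anilino. As far as these compounds go, no step beyond the scatter is therefore expected in this assay, although a modest move either way remains open. The estimated step is a 1.2-fold lower number from compound 3 to compound 4 (0.08 log units; within the scatter). For compound 4 the estimated value is 2500 nM, with an expected range of 400 nM to 9000 nM.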

Compound 4, half-maximal inhibitory concentration: 1400 nM
For compound 4 the middle estimate is 1.8-fold (0.25 log units) above the measured one; the range from low to high includes it.
By their numbers in this assay, from the lowest: compound 4; then compound 3; then compound 1. At a limit, above all of these: compound 2.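

Notes on the anilino position: in this assay, adding ethoxy in place of hydrogen on an aromatic carbon, para to a large group, gives a step beyond the scatter on its own, a 2.1-fold lower number from compound 3 to compound 4 (0.33 log units; beyond the scatter), so this place on the anilino ring responds to substitution and does not only tolerate it. Compared with the aryl group of compound 1, the (4-ethoxyphenyl)amino group gives a 5.4-fold lower number from compound 1 to compound 4 (0.73 log units; beyond the scatter), which is a wider gap than the one the unsubstituted anilino opens, a 2.5-fold lower number from compound 1 to compound 3 (0.40 log units; beyond the scatter), and compound 4 is the strongest of the four shown. The step of an at least 7.1-fold lower number from compound 2 to compound 4 (0.85 log units; beyond the scatter) is only a floor, since the value of compound 2 is a limit of the assay and not a number: the limit of > 10000 nM in this assay, at which 1 of the 4 values shown sits.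

As far as these compounds go, a single substituted anilino gives one point and no trend, so it remains open whether methoxy, a longer alkoxy chain such as butoxy, a hydroxyl or an amine at the same place would move the number in the same direction. From the compounds shown here alone, it also remains open whether the ethoxy step holds outside this assay, as all four compounds are compared in that one read-out.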